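Chloro on the phenyl ring: expected inhibition of paw edema

The source may hold more compounds than are shown below. What is called first, only, known or untested is meant among the compounds shown, and "the series" means these compounds.

Compound 1 `N#Cc1c(-c2ccc(Cl)cc2)nc(SCC(=O)Nn2c(COc3ccc(Cl)cc3Cl)nc3ccccc3c2=O)[nH]c1=O`: 64.9%
Compound 2 `Cn1c(SCC(=O)Nn2c(COc3ccc(Cl)cc3Cl)nc3ccccc3c2=O)nc(-c2ccccc2)c(C#N)c1=O`: 59.7%

In a functional assay on the whole organism (strain albino) for inhibition, with Rattus norvegicus as the target, read by paw edema, with stated times of 1 h and 3 h, at a dose of 100 mg/kg by the oral route (on this read-out lower numbers stand for a weaker effect and higher numbers for a stronger effect at the one dose given), compound 1 gives 64.9%, and compound 2 gives 59.7%, a number that differs from that of compound 1 only within the scatter of repeated measurements. Compound 3 `Cn1c(SCC(=O)Nn2c(COc3ccc(Cl)cc3Cl)nc3ccccc3c2=O)nc(-c2ccc(Cl)cc2)c(C#N)c1=O` differs from compound 2 by chloro in place of hydrogen on an aromatic carbon. For the measured compounds named here, no pair of measured compounds isolates this change on the shared core of compound 2. Compound 1, which carries a 4-chlorophenyl on a different core, shows a value within the scatter of compound 2, so the step of a number 2.3 percentage points higher from compound 2 to compound 3 (within the scatter) is expected to be small, not beyond the scatter, in either direction. Compound 3 is estimated at 62%, with a range from 50% to 74%.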

Compound 3, a percentage reported as inhibition, in the whole organism at one dose (the size of the read-out at that dose, not a potency): 73.7%
The estimate for compound 3 lay 11.7 percentage points below the measured number; measured number inside the range.
By their numbers in this assay, from the lowest: compounds 2, 1 and 3 (each within the scatter of the next, the first and the last beyond it).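

For the compounds shown here, on the shared core, phenyl to 4-chlorophenyl gives a number 14 percentage points higher from compound 2 to compound 3 (beyond the scatter) in this assay, the first single change here to go beyond the scatter. With the 4-chlorophenyl kept, methyl in place of hydrogen on an aromatic nitrogen gives a number 8.8 percentage points higher from compound 1 to compound 3 (within the scatter), so that change cannot be told from the scatter. Nothing at hand gives a reason for the chloro step. From the compounds shown here alone, whether fluoro, methoxy or an amine in the same place would match chloro stays open, and one dose does not show whether potency follows.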